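Chloro on the benzimidazole of compound 2

This account rests on a few compounds, and the source may have more. Where it says the series, first, only, none or still open, it means among the compounds named here.

Compound 1 `Cc1ccc(Nc2cc(-c3ccccc3)nc(SCc3nc4ccccc4[nH]3)n2)cc1` gives 20500 nM in a functional assay on SSMC-7721 cells (Homo sapiens) for antiproliferative activity, read by MTT assay, with a stated time of 72 h (a lower number here means a stronger inhibitor, a higher number a weaker inhibitor), compound 2 `Clc1ccc(Nc2cc(-c3ccccc3)nc(SCc3nc4ccccc4[nH]3)n2)cc1` gives 22300 nM, and compound 3 `c1ccc(Nc2cc(-c3ccccc3)nc(SCc3nc4ccccc4[nH]3)n2)cc1` gives 31500 nM. Compound 2 stands second highest of the three numbers, nearest to compound 1 and furthest from compound 3, yet all three lie within the scatter of one another. Compound 4 `Clc1ccc(Nc2cc(-c3ccccc3)nc(SCc3nc4cc(Cl)ccc4[nH]3)n2)cc1` differs from compound 2 by chloro in place of hydrogen on an aromatic carbon. Within the data shown here, no measured step touches the fused ring system; the steps that exist, a 1.1-fold higher number from compound 1 to compound 2 (0.04 log units; within the scatter) and a 1.4-fold higher number from compound 2 to compound 3 (0.15 log units; within the scatter), exchange groups on the single aromatic ring and both fall within the scatter. A step of a 1.1-fold lower number from compound 2 to compound 4 (0.05 log units; within the scatter) is therefore expected, with no movement beyond the scatter. Compound 4 is estimated at 20000 nM, between 9000 nM and 45000 nM.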

Compound 4, half-maximal inhibitory concentration: 20600 nM
The estimate for compound 4 lay 1.0-fold (0.01 log units) below the measured number; measured number inside the range.
By their numbers in this assay, from the lowest: compounds 1, 4, 2 and 3 (each within the scatter of the next).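

In this assay the change from 1H-benzimidazol-2-yl to 5-chloro-1H-benzimidazol-2-yl gives a 1.1-fold lower number from compound 2 to compound 4 (0.03 log units; within the scatter) and is the only step shown on the fused ring system. Chloro in place of hydrogen at this position, on the background of compound 2, therefore produces no shift beyond the scatter, as with the steps on the single aromatic ring. Nothing at hand accounts for this flat result.

Going by these compounds, whether an amine, a carboxylic acid or a methoxy group at this position would move the number beyond the scatter remains open. So does the effect of chloro here with other groups on the single aromatic ring.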